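Replacing a furan-2-yl carbonyl with a trihydroxyoxanyl group

The source may hold more compounds than are shown below. What is called first, only, known or untested is meant among the compounds shown, and "the series" means these compounds.

Compound 2 `CC(=O)c1ccc(O[C@@H]2O[C@H](COC(=O)c3ccco3)[C@@H](O)[C@H](O)[C@H]2O)cc1` was tested in an ADME assay on HepG2 2.2.15 cells (Homo sapiens) for cytotoxicity, read by MTT assay (a lower number here means that less compound is tolerated, a higher number that more compound is tolerated), where compound 2 gives 1170000 nM. Among the compounds with values here, its nearest neighbour is compound 1 `CC(=O)c1ccc(O[C@@H]2O[C@H](COC(=O)c3ccccc3)[C@@H](O)[C@H](O)[C@H]2O)cc1`, which in this assay gives 1050000 nM; the step of a 1.1-fold higher number from compound 1 to compound 2 (0.05 log units; within the scatter) lies within the scatter, so the two numbers cannot be told apart and compound 2 stands level with the only other compound measured. Compound 3 `CC(=O)c1ccc(O[C@@H]2O[C@H](CO[C@@H]3OC[C@@H](O)[C@H](O)[C@H]3O)[C@@H](O)[C@H](O)[C@H]2O)cc1` has not yet been measured in this assay. It differs from compound 2 as follows: 3,4,5-trihydroxyoxan-2-yl in place of (furan-2-yl)carbonyl on an oxygen on a saturated carbon. Within the data shown here, the only measured step, a 1.1-fold higher number from compound 1 to compound 2 (0.05 log units; within the scatter), exchanges one group on a carbonyl carbon for another and bears only loosely on this change; no measured pair shows the departure of the whole ((furan-2-yl)carbonyl)oxy group or the arrival of a 3,4,5-trihydroxyoxan-2-yl group. Both measured values sit far into the range where the compound is well tolerated, and nothing in the data points to a move beyond the scatter. Compound 3 is therefore expected to give about 1200000 nM in this assay, within 600000 nM to 2400000 nM. This amounts to an expected step of a 1.0-fold higher number from compound 2 to compound 3 (0.01 log units; within the scatter), within the scatter.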

Compound 3, half-maximal cytotoxic concentration: > 2590000 nM
Compound 3 gave a limit, no number (the forecaster's own chance of this, stated with the estimate: 20%); at least 2.1-fold (0.33 log units) between middle value and limit.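

The reading for compound 3 in this assay is a limit and not a number: the limit of > 2590000 nM in this assay, at which 1 of the 3 values shown sits.

Even so, this is the first change in the series to move the number beyond the scatter. With 3,4,5-trihydroxyoxan-2-yl in place of (furan-2-yl)carbonyl on an oxygen on a saturated carbon there is an at least 2.2-fold higher number from compound 2 to compound 3 (0.34 log units; beyond the scatter), and with the same group in place of benzoyl there is an at least 2.4-fold higher number from compound 1 to compound 3 (0.39 log units; beyond the scatter). Exchanging one group on the carbonyl carbon had given only a 1.1-fold higher number from compound 1 to compound 2 (0.05 log units; within the scatter), so the compounds show that replacing the whole group on this oxygen, carbonyl included, can shift the tolerated concentration upward where the exchange of furan-2-yl for phenyl could not.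

The compounds shown leave open whether the step comes from the arrival of the 3,4,5-trihydroxyoxan-2-yl group or from the departure of the carbonyl-bearing groups. A small group such as methyl or a plain hydroxyl on the same carbon would begin to separate the two, and an amine or a carboxylic acid there would show whether the trend extends to charged groups.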